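A few compounds are considered here, and "the series" means these few. Any claim that something is new, unique, unknown or untested is made for them only; others in the source may bear on it.

Measured so far:
compound 1 `CC/C(=C(/c1ccc(/C=C/C(=O)O)cc1)c1cc2ccccc2[nH]1)c1cccc(C(F)(F)F)c1` gives 325 nM;
compound 2 `CC/C(=C(/c1ccc(/C=C/C(=O)O)cc1)c1cc2ccccc2[nH]1)c1ccc(C#N)cc1` gives 278 nM;
compound 3 `CC/C(=C(/c1ccc(/C=C/C(=O)O)cc1)c1cc2ccccc2[nH]1)c1ccc(C(F)(F)F)cc1Cl` gives 27 nM.

In a functional assay on MCF7 cells (Homo sapiens) for inhibition (on this read-out lower numbers stand for stronger inhibition and higher numbers for weaker inhibition), compound 2 stands second highest of the three numbers: the step of a 1.2-fold lower number from compound 1 to compound 2 (0.07 log units; within the scatter) is within the scatter, whereas the step of a 10-fold lower number from compound 2 to compound 3 (1.01 log units; beyond the scatter) is large. Compound 4 `CC/C(=C(/c1ccc(/C=C/C(=O)O)cc1)c1cc2ccccc2[nH]1)c1ccc(Cl)c(C(F)(F)F)c1` is unmeasured; the change from compound 2 is 4-chloro-3-(trifluoromethyl)phenyl in place of 4-cyanophenyl on a double-bonded chain carbon bound to a double-bonded chain carbon and a saturated chain carbon. Going by the values given here, the steps that bear on it are a 10-fold lower number from compound 2 to compound 3 (1.01 log units; beyond the scatter) and a 12-fold lower number from compound 1 to compound 3 (1.08 log units; beyond the scatter), both large, and both bring in a ring carrying chloro and trifluoromethyl together. Among the compounds with values here, compound 4 also carries both, but its group name differs from that of compound 3, and no measured step tests this arrangement. A step of a 2.8-fold lower number from compound 2 to compound 4 (0.44 log units; beyond the scatter) toward a lower number is therefore expected for compound 4, with an estimate of 100 nM and a range of 30 nM to 300 nM.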

Compound 4, half-maximal inhibitory concentration: 2200 nM
Estimate against measurement, compound 4: 22-fold (1.34 log units) below; measured number above the stated range.
By their numbers in this assay, from the lowest: compound 3; then compounds 2 and 1 (each within the scatter of the next); then compound 4.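

The step of an 81-fold higher number from compound 3 to compound 4 (1.91 log units; beyond the scatter) in this assay separates two rings that both carry chloro and trifluoromethyl, so having the two groups together does not secure a low number at this double-bonded chain carbon; their arrangement on the ring matters. Chloro in place of hydrogen on an aromatic carbon gives a 6.8-fold higher number from compound 1 to compound 4 (0.83 log units; beyond the scatter) and so moves away from compound 3. The change from 4-cyanophenyl gives a 7.9-fold higher number from compound 2 to compound 4 (0.90 log units; beyond the scatter) in the same direction.

Still open, going by these compounds, is how a 2-chlorophenyl ring, or methoxy in place of trifluoromethyl on the compound 3 ring, would read at this carbon. No measured evidence accounts for these differences.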